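The source may hold more compounds than are shown below. What is called first, only, known or untested is meant among the compounds shown, and "the series" means these compounds.

Measured so far in this series:
compound 1 `COC(=O)c1c(Br)cc(Br)cc1OC(=O)COc1cc(O)c2c(=O)cc(-c3ccccc3)oc2c1` — 398000 nM
compound 2 `COC(=O)c1ccc(C)cc1OC(=O)COc1cc(O)c2c(=O)cc(-c3ccccc3)oc2c1` — 250000 nM
compound 3 `COC(=O)c1cccc(OC)c1OC(=O)COc1cc(O)c2c(=O)cc(-c3ccccc3)oc2c1` — 196000 nM

Three compounds of the shared core have been run in an ADME assay on cells (T-cell, Mus musculus, strain BALB/c) for cytotoxicity, read by MTT assay, with a stated time of 48 h; a higher number here means that more compound is tolerated, a lower number that less compound is tolerated. Compound 1 gives 398000 nM, compound 3 gives 196000 nM, and compound 2 gives 250000 nM. Among these three numbers compound 2 is the second highest, but its distance to compound 3 and its distance to compound 1 are both within the usual scatter of repeat measurements, so the three compounds cannot be told apart on this assay.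

Compound 4 `COC(=O)c1c(C)cccc1OC(=O)COc1cc(O)c2c(=O)cc(-c3ccccc3)oc2c1` has not yet been measured. It differs from compound 2 in one place: a group of 11 heavy atoms (9 carbon, 2 oxygen; one six-membered aromatic ring of carbon only) in place of a group of 11 heavy atoms (9 carbon, 2 oxygen; one six-membered aromatic ring of carbon only), on an oxygen next to a carbonyl group. The two compounds have the same atoms, joined differently.

Among the measured compounds shown here, no step between measured compounds is available to calibrate a change of this kind. The three groups so far placed on an oxygen next to a carbonyl group all land within the scatter of each other, so no step beyond the scatter is expected in this assay from compound 2 to compound 4. Compound 4 is therefore estimated at 250000 nM, with a range from 120000 nM to 500000 nM. The expected step of no change at the digits printed from compound 2 to compound 4 (within the scatter) lies within the scatter.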

Compound 4, half-maximal cytotoxic concentration: 298000 nM
For compound 4 the middle estimate is 1.2-fold (0.08 log units) below the measured one; measured number inside the range.
By their numbers in this assay, from the lowest: compounds 3, 2, 4 and 1 (each within the scatter of the next, the first and the last beyond it).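

Working notes on the series: in this assay the change of one group for another made of the same atoms gives the first step between compounds that differ in one place, a 1.2-fold higher number from compound 2 to compound 4 (0.08 log units; within the scatter) and this step lies within the scatter. On an oxygen next to a carbonyl group, then, joining the atoms of this group of 11 heavy atoms differently, with its one six-membered aromatic ring of carbon only kept, leaves compound 2 and compound 4 indistinguishable in this assay and gives this position no calibrated effect of any size beyond the scatter. Nothing at hand bears on the reason for this result, so the step stands as a plain observation and no more.

The compounds shown leave open whether a group of a different kind on this oxygen, such as one carrying a carboxylic acid or an amine in place of the methyl ester, or a longer chain in place of the aromatic ring, would give a step beyond the scatter. They also leave open whether the shared core itself sets the level of tolerance seen here, since every compound shown carries it unchanged.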